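Replacing an Arylamino Group with a Saturated Ring

The source may hold more compounds than are shown below. What is called first, only, known or untested is meant among the compounds shown, and "the series" means these compounds.

Of the compounds shown here, two have been tested so far in a functional assay on HCT-116 cells (Homo sapiens) for antiproliferative activity, read by CCK-8 assay, with a stated time of 72 h, tested at 8 uM; a lower number here means a weaker effect, a higher number a stronger effect of the compound at the concentration tested. Compound 1 `CC1CCN(c2nc(Cl)nc3c2ncn3Cc2ccc(/C=C/C(=O)Nc3ccccc3N)cc2)CC1` gives 26.9%. Compound 2 `Nc1ccccc1NC(=O)c1ccc(Cn2cnc3c(Nc4cccc(OC(F)(F)F)c4)nc(Cl)nc32)cc1` gives 46.6% in this assay, the higher of the two numbers, and the gap between them lies beyond the usual scatter. Compound 3 `CC1CCN(c2nc(Cl)nc3c2ncn3Cc2ccc(C(=O)Nc3ccccc3N)cc2)CC1` has not yet been measured. It is built from compound 2 by a single change: 4-methylpiperidin-1-yl in place of (3-(trifluoromethoxy)phenyl)amino on an aromatic carbon. The group that enters is the same one carried by compound 1, whose result of 26.9% is the lower of the two measured values. Among the compounds with values here, no pair of measured compounds isolates this exact exchange on its own, so any expectation rests on that single comparison. The step from compound 2 to compound 3 is expected to be downward and beyond the scatter, a number 16.6 percentage points lower from compound 2 to compound 3 (beyond the scatter). Compound 3 is accordingly estimated at 30%, within a range from 15% to 45%.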

Compound 3, a percentage reported as inhibition, at one concentration (the size of the read-out at that concentration, not a potency): 78.6%
Compound 3: the middle estimate sits 48.6 percentage points below what was measured, outside the stated range (above it).
By their numbers in this assay, from the lowest: compound 1; then compound 2; then compound 3.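

In this assay, 4-methylpiperidin-1-yl in place of (3-(trifluoromethoxy)phenyl)amino gives a number 32 percentage points higher from compound 2 to compound 3 (beyond the scatter), so in this pair, a saturated ring with no hydrogen-bond donor in the exchanged group outperforms the arylamino group at the concentration tested. The low number of compound 1 therefore says little about 4-methylpiperidin-1-yl on its own: with that group held constant, (2-aminophenyl)carbamoyl in place of 2-((2-aminophenyl)carbamoyl)ethenyl gives a number 51.7 percentage points higher from compound 1 to compound 3 (beyond the scatter). No measured property is available to explain either step.

The compounds shown cannot separate the contribution of the methyl group from that of the ring, a question that unsubstituted piperidin-1-yl, morpholin-4-yl or dimethylamino at this position would address. Also open, from the compounds shown here alone, is whether the exchange would give a step of similar direction and size with the ethenyl-containing side chain, and these single-concentration percentages give no potency.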